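Working notes: from compound 2 to compound 4

This account rests on a few compounds, and the source may have more. Where it says the series, first, only, none or still open, it means among the compounds named here.

Measured in a physicochemical assay for solubility, at pH 6.8; a lower number here means a less soluble compound, a higher number a more soluble compound:
- compound 1 `CN(C)Cc1ccc(-c2cnc(N)c(C(=O)NC3CCCC3O)n2)cc1`: 940000 nM
- compound 2 `CCN(CC)Cc1ccc(-c2cnc(N)c(C(=O)NC[C@@](C)(O)C(F)(F)F)n2)cc1`: > 1000000 nM (a limit of the assay, not a number)
- compound 3 `CN(C)Cc1ccc(-c2cnc(N)c(C(=O)NCC(O)C(F)(F)F)n2)cc1`: 880000 nM

Compound 2 has no exact number in this assay. It stands at the limit of > 1000000 nM in this assay, at which 1 of the 3 values shown sits, and that entry is a limit only.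

Compound 4 `C[C@@](O)(CNC(=O)c1nc(-c2ccc(CN3CCCC3)cc2)cnc1N)C(F)(F)F` is the next compound to read. The change from compound 2 is pyrrolidin-1-yl in place of diethylamino on a saturated chain carbon bound to an aromatic carbon. In short, pyrrolidin-1-yl replaces diethylamino on a saturated chain carbon bound to an aromatic carbon, and the rest of the structure stays the same.

For the measured compounds named here, no measured step covers this place. Going by the values given here, the only measured step, a 1.1-fold lower number from compound 1 to compound 3 (0.03 log units; within the scatter), sits on an amide-type nitrogen and stays within the scatter, so it offers only weak guidance. With nothing pointing either way, no change beyond the scatter is expected. The expected step in this assay is an at least 1.0-fold lower number from compound 2 to compound 4 (0.02 log units; that floor lies within the scatter), and a reading at the limit would be no surprise.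

Compound 4 is estimated at 950000 nM, with an expected range of 550000 nM to 1000000 nM.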

Compound 4, solubility: > 1000000 nM
Compound 4: no number, only a limit; the forecaster's own chance of this, stated with the estimate: 45%; at least 1.0-fold (0.02 log units) between middle value and limit.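

In this assay compound 2 gives > 1000000 nM, a limit and not a number. Compound 4 gives > 1000000 nM, also a limit, so no step can be read between compound 2 and compound 4. Left open is whether pyrrolidin-1-yl in place of diethylamino shifts the read-out in this assay at all.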